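A few compounds are considered here, and "the series" means these few. Any claim that something is new, unique, unknown or untested is made for them only; others in the source may bear on it.

Among the measured compounds shown here, compound 1, with the structure `COc1ccccc1S(=O)(=O)/C=C/c1ccccn1`, is one of three compounds measured so far in an assay on U2OS cells for activation of nuclear factor erythroid 2-related factor 2 (Homo sapiens), read by chemiluminescence, with a stated time of 6 h; on this read-out higher numbers stand for an effect only at larger amounts of compound and lower numbers for an effect already at smaller amounts. In this assay compound 1 gives 9070 nM. Compound 2, with the structure `COc1ccccc1S(=O)(=O)/C=C/c1ncccc1Cl`, gives 142 nM in this assay. The change between them is chloro in place of hydrogen on an aromatic carbon, and it produced a 64-fold lower number from compound 1 to compound 2 (1.81 log units; beyond the scatter).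

Compound 3, with the structure `COc1ccc(S(=O)(=O)/C=C/c2cccnc2)cc1`, shares its atoms with compound 1 but has them joined differently; how the two cores differ is not broken down here. For compound 3 this assay reports only a limit, > 10000 nM, so no number is known for it, only that it sits at the limit of > 10000 nM in this assay, at which 1 of the 3 values shown sits.

Compound 4, with the structure `COc1ccc(S(=O)(=O)/C=C/c2cccnc2Cl)cc1`, has not been measured. It differs from compound 3 by chloro in place of hydrogen on an aromatic carbon. For the measured compounds named here, this is the same kind of change as the one from compound 1 to compound 2, not the same: there the chloro sits two atoms from the ring nitrogen, here it sits next to the ring nitrogen. Because the same kind of change gave a 64-fold lower number from compound 1 to compound 2 (1.81 log units; beyond the scatter) in this assay, a step of roughly that direction from compound 3 to compound 4 is expected, though its size cannot be anchored since compound 3 has only a limit. The step from compound 3 to compound 4 is expected to be about an at least 6.6-fold lower number from compound 3 to compound 4 (0.82 log units; beyond the scatter). For compound 4 the estimated value in this assay is 1500 nM, with a likely range from 200 nM to 10000 nM.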

Compound 4, half-maximal effective concentration: 955 nM
Compound 4: middle estimate off by 1.6-fold (0.20 log units), on the high side; the measured number falls inside the stated range.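

In this assay, chloro in place of hydrogen on an aromatic carbon again lowered the number, giving an at least 10-fold lower number from compound 3 to compound 4 (1.01 log units; beyond the scatter), so the change pointed the same way on both cores. Two pairs show a shared direction and not a rule for every core in this series, and they do not settle whether the change is worth more on one core than on the other: the same change on two cores in this assay, a 64-fold lower number (1.81 log units; beyond the scatter) from compound 1 to compound 2 and an at least 10-fold lower number (1.01 log units; beyond the scatter) from compound 3 to compound 4; the limit leaves it open whether they differ. As far as these compounds go, compound 3 is held only as a limit, so the true size of its step stays unknown: the limit of > 10000 nM in this assay, at which 1 of the 4 values shown sits.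

The compounds shown leave open whether another group on the same aromatic carbon, such as fluoro, bromo, methyl or an amine, would lower the number as chloro does, or whether this effect belongs to chloro alone. They also leave open what a chloro would do on other aromatic carbons of these two cores, and whether the methoxy group on the other ring, which differs in place between the two cores, could be replaced by a longer chain such as ethoxy without losing the gain.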